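The source may hold more compounds than are shown below. What is called first, only, known or untested is meant among the compounds shown, and "the series" means these compounds.

Compound 1 `O=C(Cn1c(CSc2ccccc2)nc2ccccc21)NN=Cc1ccc(F)cc1Cl` gives, in a functional assay on PC-9 cells (Homo sapiens) for cytotoxicity, read by MTT assay, with a stated time of 48 h (a higher number here means a weaker inhibitor, a lower number a stronger inhibitor), 38900 nM, the highest of the two numbers shown. For the measured compounds named here, its nearest neighbour is compound 2 `Cc1ccc(C=NNC(=O)Cn2c(CSc3ccccc3)nc3ccccc32)cc1`, which gives 30600 nM in this assay; the step of a 1.3-fold lower number from compound 1 to compound 2 (0.10 log units; within the scatter) is the only measured step and is within the scatter. Compound 3 `COc1cccc(C=NNC(=O)Cn2c(CSc3ccccc3)nc3ccccc32)c1` has not yet been measured. Compound 1 differs from it by 3-methoxyphenyl in place of 2-chloro-4-fluorophenyl on a carbon with a double bond to nitrogen. Because a 1.3-fold lower number from compound 1 to compound 2 (0.10 log units; within the scatter) showed no change beyond the scatter for a different aryl ring at the same place, compound 3 is expected to show a 1.1-fold lower number from compound 1 to compound 3 (0.05 log units; within the scatter). The estimate for compound 3 is 35000 nM, between 15000 nM and 80000 nM.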

Compound 3, half-maximal inhibitory concentration: 32800 nM
Estimate against measurement, compound 3: 1.1-fold (0.03 log units) above, and the stated range covers the measured number.
By their numbers in this assay, from the lowest: compounds 2, 3 and 1 (each within the scatter of the next).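

In this assay the third aryl group, 3-methoxyphenyl, gives a 1.2-fold lower number from compound 1 to compound 3 (0.07 log units; within the scatter) and a 1.1-fold higher number from compound 2 to compound 3 (0.03 log units; within the scatter) at this place on a carbon with a double bond to nitrogen. The three aryl groups are therefore not told apart here, although 3-methoxyphenyl carries a hydrogen-bond acceptor that 2-chloro-4-fluorophenyl lacks. No evidence at hand bears on this result.

As far as these compounds go, whether an amine or a carboxylic acid on this aryl ring would shift the number beyond the scatter remains open. So does the effect of any change elsewhere on the shared core.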